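The source may report more compounds than this note shows. Statements on the series, on what has been measured and on what is new or still open speak of the compounds shown alone.

Of the compounds shown here, three built on a shared core have been measured so far: compound 1 (`CN(C)Cc1ccc2nc(NC(=O)N/N=C/c3ccccn3)sc2c1`), compound 2 (`C/C(=N\NC(=O)Nc1nc2ccc(CN(C)C)cc2s1)c1ccccn1`) and compound 3 (`CN(C)Cc1ccc2nc(NC(=O)NN=C(c3ccccn3)c3ccccn3)sc2c1`). In a functional assay on U-937 cells (Homo sapiens) for antiproliferative activity, read by CCK-8 assay, with a stated time of 24 h (a higher number here means a weaker inhibitor, a lower number a stronger inhibitor), compound 2 gives 20100 nM and so stands second highest of the three numbers. Compound 1 gives 23200 nM and this lies within the usual scatter of compound 2, so the two cannot be told apart. Compound 3 gives 7800 nM and this is a lower number than that of compound 2, beyond the scatter, which makes it the stronger inhibitor of that pair.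

The next compound is compound 4 (`C/C(=N\NC(=O)Nc1nc2ccc(CN(C)C)cc2s1)c1cnccn1`), which has not yet been measured in this assay. It differs from compound 2 by pyrazin-2-yl in place of pyridin-2-yl on a carbon with a double bond to nitrogen. Among the compounds with values here, no pair measured so far shows this swap directly, so the data offer no guide to a shift in either direction. The natural starting point is therefore compound 2 at 20100 nM and no change beyond the scatter is expected. The expected size of the step is a 1.0-fold higher number from compound 2 to compound 4 (0.02 log units; within the scatter) and an estimate this close carries no firm direction. Compound 4 is estimated at 21000 nM (expected range 9000 nM to 45000 nM).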

Compound 4, half-maximal inhibitory concentration: > 40000 nM
Compound 4: only a limit was reported (the forecaster's own chance of this, stated with the estimate: 8%); at least 1.9-fold (0.27 log units) between middle value and limit.
By their numbers in this assay, from the lowest: compound 3; then compounds 2 and 1 (each within the scatter of the next). At a limit, above all of these: compound 4.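

In this assay, compound 4 gives > 40000 nM, which is a limit of the assay and not a measured number. Within the data shown here, this is the first view of a change to the ring on the carbon with a double bond to nitrogen, and swapping pyridin-2-yl for pyrazin-2-yl, which carries a second ring nitrogen, gives an at least 1.9-fold higher number from compound 2 to compound 4 (0.29 log units; that floor lies within the scatter), so the swap brings no gain in strength at this position, though the printed floor alone does not establish a real loss. The result therefore gives a direction that can only be read as a lower bound, and its size stays capped by how far the assay reaches: the limit of > 40000 nM in this assay, at which 1 of the 4 values shown sits.

The compounds shown leave open how large this step really is, and whether it truly goes beyond the usual scatter of repeated measurements. They also leave open what a phenyl ring, with carbon atoms only, or a pyridin-2-yl ring carrying an added amine would do on this same carbon, which would help show whether the ring nitrogens matter here at all.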